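Stilbene series: isopropyl replacing methylsulfanyl

The source may hold more compounds than are shown below. What is called first, only, known or untested is meant among the compounds shown, and "the series" means these compounds.

Among the measured compounds shown here, compound 2 `COc1cc(/C=C\c2ccc(SC)cc2)cc(OC)c1OC` holds the highest of the two numbers measured so far in a functional assay on MCF7 cells (Homo sapiens) for cytotoxicity (a higher number here means that more compound is needed for the effect, a lower number that less compound is needed), where compound 2 gives 5.4 uM. Compound 1 `COc1cc(/C=C\c2ccc(C(C)(C)C)cc2)cc(OC)c1OC` gives 1.57 uM. For the measured compounds named here, the single measured step, a 3.4-fold higher number from compound 1 to compound 2 (0.54 log units; beyond the scatter), bears on the change to compound 3 `COc1cc(/C=C\c2ccc(C(C)C)cc2)cc(OC)c1OC`: isopropyl in place of methylsulfanyl on an aromatic carbon. Since isopropyl, like the tert-butyl of compound 1, is built of carbon only, a move back toward the number of compound 1 is expected, a modest step of a 2.2-fold lower number from compound 2 to compound 3 (0.33 log units; beyond the scatter). Compound 3 is therefore estimated at 2.5 uM, with a range from 1.2 uM to 5 uM.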

Compound 3, concentration for half-maximal effect: 1.4 uM
Compound 3: middle estimate off by 1.8-fold (0.25 log units), on the high side; low and high end bracket the measured number.
By their numbers in this assay, from the lowest: compounds 3 and 1 (each within the scatter of the next); then compound 2.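

At this place on the aromatic ring, isopropyl in place of methylsulfanyl gives a 3.9-fold lower number from compound 2 to compound 3 (0.59 log units; beyond the scatter), so two carbon-only groups now stand on the low side of methylsulfanyl. Shortening tert-butyl to isopropyl gives a 1.1-fold lower number from compound 1 to compound 3 (0.05 log units; within the scatter), and these two groups are not told apart here. Nothing on hand accounts for either step.

On these data alone, whether the low numbers extend to an ethyl group, or hold at all for an amine or a carboxylic acid here, stays open. Also open, as far as these compounds go, is whether the number for methylsulfanyl follows from its sulfur or from the group as a whole.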